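From thiophen-2-yl to phenyl on a carbonyl carbon

A few compounds are considered here, and "the series" means these few. Any claim that something is new, unique, unknown or untested is made for them only; others in the source may bear on it.

Going by the values given here, compound 2 `O=C(C=CNc1cc(-c2ccccc2)nn1-c1ccccc1)c1cccs1` gives 19900 nM in an ADME assay on THLE-2 cells (Homo sapiens) for cytotoxicity, read by MTT assay (a lower number here means that less compound is tolerated, a higher number that more compound is tolerated), and stands within the scatter of compound 1 `COc1ccc(C(=O)C=CNc2cc(-c3ccccc3)nn2-c2ccccc2)cc1` at 35200 nM as the only other measured number. Compound 3 `O=C(C=CNc1cc(-c2ccccc2)nn1-c1ccccc1)c1ccccc1` carries phenyl in place of thiophen-2-yl on a carbonyl carbon, with phenyl in place of thiophen-2-yl on a carbonyl carbon as the counted difference. Among the compounds with values here, the one measured step at this place is a 1.8-fold lower number from compound 1 to compound 2 (0.25 log units; within the scatter) and it put thiophen-2-yl in place of 4-methoxyphenyl without leaving the scatter. No step beyond the scatter is therefore expected in this assay for this change. Compound 3 is estimated at 26000 nM with an expected range from 12000 nM to 55000 nM for its measurement. The estimate amounts to a 1.3-fold higher number from compound 2 to compound 3 (0.12 log units; within the scatter) as an expected step inside the scatter.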

Compound 3, half-maximal cytotoxic concentration: 53400 nM
For compound 3 the middle estimate is 2.1-fold (0.31 log units) below the measured one, and the stated range covers the measured number.
By their numbers in this assay, from the lowest: compounds 2, 1 and 3 (each within the scatter of the next, the first and the last beyond it).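

In this assay, going by these compounds alone, phenyl in place of thiophen-2-yl gives the first step at this place to lie beyond the scatter, though only a modest one (a 2.7-fold higher number from compound 2 to compound 3 (0.43 log units; beyond the scatter)). Hydrogen in place of methoxy on an aromatic carbon stays within the scatter (a 1.5-fold higher number from compound 1 to compound 3 (0.18 log units; within the scatter)). Compound 1 thus lies within the scatter of both compound 2 and compound 3, and only the last two stand apart. Nothing at hand explains this step. Going by these compounds, whether an amine or a carboxylic acid on the phenyl ring would move the number remains open.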